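Swapping the sulfamoyl group of compound 2

The compounds below may be only part of what the source reports. "The series", "measured", "known", "first", "only" and "open" are said of these compounds alone.

Measured in an ADME assay (liver) for metabolic stability, with Liver microsome (Rattus norvegicus) as the target, using microsomes and NADPH, with a stated time of 30 min, at 37 degrees C, tested at 1 uM; on this read-out lower numbers stand for slow clearance and higher numbers for fast clearance:
Compound 1 `CC(O)(c1ccc(-c2ncc(S(=O)(=O)c3ccc(N)nc3)s2)c(Cl)c1)C(F)(F)F`: < 14 mL.min-1.g-1, a limit of the assay
Compound 2 `Nc1ccc(S(=O)(=O)c2cnc(-c3ccc(S(N)(=O)=O)cc3Cl)s2)cn1`: 107 mL.min-1.g-1

Within the data shown here, compound 2 carries the only true number so far, and the one other result is a limit. Compound 3 `CC(O)(CO)c1ccc(-c2ncc(S(=O)(=O)c3ccc(N)nc3)s2)c(Cl)c1` keeps the shared core but has 1-hydroxy-1-(hydroxymethyl)ethyl in place of sulfamoyl on an aromatic carbon. Among the measured compounds shown here, only one measured step bears on this change, and it involves the same sulfamoyl group. Going by an at least 7.6-fold higher number from compound 1 to compound 2 (0.88 log units; beyond the scatter), read backwards, a clear drop in this assay is expected when sulfamoyl leaves, since the group entering compound 3 has a closely similar name. A single step with a different group is thin support, so the drop may be smaller. The expected change is a 4.3-fold lower number from compound 2 to compound 3 (0.63 log units; beyond the scatter). For compound 3 the estimated value is 25 mL.min-1.g-1, with a range of 14 mL.min-1.g-1 to 70 mL.min-1.g-1.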

Compound 3, intrinsic clearance in microsomes: < 14 mL.min-1.g-1
Compound 3 gave a limit, no number (the forecaster's own chance of this, stated with the estimate: 30%); middle value at least 1.7-fold (0.25 log units) from the limit.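

In this assay, a second, different group in place of sulfamoyl on this aromatic carbon also brings the number down, with 1-hydroxy-1-(hydroxymethyl)ethyl giving an at least 7.6-fold lower number from compound 2 to compound 3 (0.88 log units; beyond the scatter). Compound 3 gives < 14 mL.min-1.g-1, which is a limit of the assay and not a number. The high number now stands with sulfamoyl alone among the three compounds, while the two groups that carry a hydroxy group cannot be ranked against each other, and the true size of the drop stays hidden, because the read-out stops at the same limit: the limit of < 14 mL.min-1.g-1 in this assay, at which 2 of the 3 values shown sit.

From the compounds shown here alone, whether any group other than sulfamoyl at this place would also give a high number remains open. An amine, a carboxylic acid or a longer chain carrying a hydroxy group could show how far this holds.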